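Swapping the Amide Aryl Ring: Compound 3 to Compound 4

This account rests on a few compounds, and the source may have more. Where it says the series, first, only, none or still open, it means among the compounds named here.

Of the compounds shown here, three sharing one core have been tested in a functional assay on HepG2 cells (Homo sapiens), read by MTT assay, with a stated time of 72 h; on this read-out lower numbers stand for stronger inhibition and higher numbers for weaker inhibition. Compound 1 `O=C(Oc1ccc(Cl)cc1C(=O)Nc1ccc(Cl)c(Cl)c1)c1ccc(Br)cc1` gives 2500 nM, and compound 2 `Cc1ccc(C(=O)Oc2ccc(Cl)cc2C(=O)Nc2ccc(Cl)c(Cl)c2)cc1` gives 2550 nM; the change a 1.0-fold higher number from compound 1 to compound 2 (0.01 log units; within the scatter) shows that swapping these two groups on the ester side leaves the number essentially unchanged. Compound 3 `O=C(Oc1ccc(Cl)cc1C(=O)Nc1ccc(C(F)(F)F)cc1)c1ccc([N+](=O)[O-])cc1` gives 1150 nM, the lowest of the three numbers and beyond the scatter from both of the others, so on these data it is the most potent compound.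

Compound 4 `O=C(Oc1ccc(Cl)cc1C(=O)Nc1ccc(Cl)c(Cl)c1)c1ccc([N+](=O)[O-])cc1` differs from compound 3 in one place: 3,4-dichlorophenyl in place of 4-(trifluoromethyl)phenyl on an amide-type nitrogen. For the measured compounds named here, no measured pair isolates this change; compounds 1 and 2 carry the same 3,4-dichlorophenyl group as compound 4 but also a different ester, so their comparison with compound 3 mixes two changes. Going by the values given here, the only clean step, from compound 1 to compound 2, concerns the ester side and does not inform the amide change. The expected step is therefore a 1.3-fold higher number from compound 3 to compound 4 (0.12 log units; within the scatter), with a wide range. Compound 4 is estimated at 1500 nM, between 500 nM and 4500 nM.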

Compound 4, half-maximal inhibitory concentration: 3550 nM
Compound 4: middle estimate off by 2.4-fold (0.37 log units), on the low side; the measured number falls inside the stated range.
By their numbers in this assay, from the lowest: compound 3; then compounds 1, 2 and 4 (each within the scatter of the next).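

In this assay, for the compounds shown here, the amide side gives the first clean step at this position: with the ester side held fixed, 3,4-dichlorophenyl in place of 4-(trifluoromethyl)phenyl on the amide-type nitrogen gives a 3.1-fold higher number from compound 3 to compound 4 (0.49 log units; beyond the scatter), so this change moves the number. On the ester side, with 3,4-dichlorophenyl kept, nitro in place of methyl gives a 1.4-fold higher number from compound 2 to compound 4 (0.14 log units; within the scatter) and nitro in place of bromo gives a 1.4-fold higher number from compound 1 to compound 4 (0.15 log units; within the scatter), so the nitro group alone does not set compound 4 apart from those two. Nothing available explains why the amide swap shifts the number.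

Going by these compounds alone, only two groups on the amide-type nitrogen appear here, so it stays open how a phenyl ring carrying a single chlorine, a methoxy group or an amine would compare. From the compounds shown here alone, it also stays open whether 4-(trifluoromethyl)phenyl would keep its lower number with bromo or methyl on the ester side.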